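This account rests on a few compounds, and the source may have more. Where it says the series, first, only, none or still open, it means among the compounds named here.

Measured so far:
compound 1 `CCC(NC(=O)C(CC(C)C)NC(=O)OCc1ccccc1)C(=O)C(=O)NCCCCCO` — 51 nM
compound 2 `CCC(NC(=O)C(CC(C)C)NC(=O)OCc1ccccc1)C(=O)C(=O)NCC1(C)CC(O)CC(C)(C)C1` — 69 nM
compound 3 `CCC(NC(=O)C(CC(C)C)NC(=O)OCc1ccccc1)C(=O)C(=O)NCc1cccnc1` — 120 nM

These three values come from an assay on isolated protein (Oryctolagus cuniculus) for inhibition of Calpain-2 catalytic subunit (Homo sapiens); a higher number here means a weaker inhibitor, a lower number a stronger inhibitor. Compound 3 has the highest number of the three; one of its two steps, a 2.4-fold higher number from compound 1 to compound 3 (0.37 log units; beyond the scatter), lies beyond the scatter, while the other, a 1.7-fold higher number from compound 2 to compound 3 (0.24 log units; within the scatter), stays within the scatter, so no order between compound 2 and compound 3 can be claimed.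

Compound 4 `CCC(NC(=O)C(CC(C)C)NC(=O)OCc1ccccc1)C(=O)C(=O)NCc1ccc2ccccc2n1` carries the change (quinolin-2-yl in place of pyridin-3-yl on a saturated chain carbon bound to an amide-type nitrogen). The two steps that touch the same position are a 1.4-fold higher number from compound 1 to compound 2 (0.13 log units; within the scatter) and a 2.4-fold higher number from compound 1 to compound 3 (0.37 log units; beyond the scatter): a larger group in place of a smaller one left the number within the scatter, and the aromatic ring in place of the chain gave a modest rise. Nothing here points to a large move in this assay for a larger aromatic group.

Compound 4 is therefore expected near 120 nM, with a range of 40 nM to 350 nM. The step expected from compound 3 to compound 4 is no change at the digits printed from compound 3 to compound 4 (within the scatter), not beyond the scatter.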

Compound 4, inhibition constant: 600 nM
Beside the measured number, compound 4's estimate is 5.0-fold (0.70 log units) below it; the measured number lies above the stated range.
By their numbers in this assay, from the lowest: compounds 1, 2 and 3 (each within the scatter of the next, the first and the last beyond it); then compound 4.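

Two aromatic groups at this position are not interchangeable in this assay: quinolin-2-yl in place of pyridin-3-yl gives a 5.0-fold higher number from compound 3 to compound 4 (0.70 log units; beyond the scatter) and goes beyond the scatter. Heavy-atom count alone does not set the number, as groups of equal count give an 8.7-fold higher number from compound 2 to compound 4 (0.94 log units; beyond the scatter) and the chain comparison gives a 12-fold higher number from compound 1 to compound 4 (1.07 log units; beyond the scatter) with the 4-hydroxybutyl group leaving. No measured evidence bears on this rise.

Still open, going by these compounds, is whether the added carbon-only aromatic ring or the change from a 3-yl to a 2-yl attachment carries the rise. A pyridin-2-yl group at this place would separate the two.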